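The source may hold more compounds than are shown below. What is called first, only, known or untested is meant among the compounds shown, and "the series" means these compounds.

Compounds measured so far in a functional assay on ECa-109 cells for inhibition, with ECa-109 cell line (Homo sapiens) as the target, read by sulforhodamine B assay; a lower number here means a stronger inhibitor, a higher number a weaker inhibitor:
- compound 1 `O=C1C(Nc2cccc(Cl)c2)=CC(=O)c2c1nc1n2[C@H]2OC[C@@H](O)[C@H]2OC1`: 3080 nM
- compound 2 `CCOc1ccccc1NC1=CC(=O)c2nc3n(c2C1=O)[C@H]1OC[C@@H](O)[C@H]1OC3`: 4630 nM
- compound 3 `CCOc1ccc(NC2=CC(=O)c3nc4n(c3C2=O)[C@H]2OC[C@@H](O)[C@H]2OC4)cc1`: 3210 nM

All three share one core and differ only in the substituted phenyl ring carried on the amine nitrogen. Their numbers lie close together: compound 1 gives 3080 nM, compound 3 gives 3210 nM, and no gap among the three is beyond the usual scatter, so none of them can be called stronger or weaker than another. Among the compounds with values here, the one measured step that alters the phenyl ring, a 1.4-fold lower number from compound 2 to compound 3 (0.16 log units; within the scatter), moves the ethoxy group from one position to another and stays within the scatter.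

Compound 4 `O=C1C(Nc2ccc(Br)cc2)=CC(=O)c2c1nc1n2[C@H]2OC[C@@H](O)[C@H]2OC1` has not been measured. It differs from compound 1 in a single place: 4-bromophenyl in place of 3-chlorophenyl on an amine nitrogen. Within the data shown here, no measured step swaps one halogen for another, so only the general observation remains that changing the substituent on this phenyl ring, as in the step from compound 2 to compound 3, produced no shift beyond the scatter. On that basis, compound 4 is expected to stay close to compound 1, and the step of a 1.0-fold lower number from compound 1 to compound 4 (0.01 log units; within the scatter) is estimated to lie within the scatter. The estimate for compound 4 in this assay is 3000 nM, with a range from 1200 nM to 7500 nM.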

Compound 4, half-maximal inhibitory concentration: 1980 nM
Beside the measured number, compound 4's estimate is 1.5-fold (0.18 log units) above it, and the stated range covers the measured number.
By their numbers in this assay, from the lowest: compounds 4, 1, 3 and 2 (each within the scatter of the next, the first and the last beyond it).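

In this assay the change from 3-chlorophenyl to 4-bromophenyl on the amine nitrogen gives a 1.6-fold lower number from compound 1 to compound 4 (0.19 log units; within the scatter) and so does not separate the two compounds, even though both the halogen and its place on the ring differ. Within the data shown here, the earlier compounds showed only an ethoxy group in two different places, so this is the first step showing that a change of halogen on this ring can also stay within the scatter. The new number does widen the set at its ends: compound 4 at 1980 nM and compound 2 at 4630 nM now lie beyond the scatter of each other, although each compound in the order stays within the scatter of the next.

Because both features change in this one step, the effect of the halogen cannot be told from that of its place, and 4-chlorophenyl on the same nitrogen would separate them. It also remains open whether a plain phenyl ring, or one carrying a carboxylic acid or a dimethylamino group, would shift the number beyond the scatter, and nothing shown gives any reason for the small differences seen here.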